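The compounds below may be only part of what the source reports. "The series", "measured", "known", "first", "only" and "open" are said of these compounds alone.

In a functional assay on MCF7 cells (Homo sapiens) for inhibition, read by MTT assay (on this read-out lower numbers stand for stronger inhibition and higher numbers for weaker inhibition), two compounds sharing one core have been measured so far. Compound 1 `COc1cc2ncnc(Nc3ccc(NC(=O)c4cccc(C)c4)cc3)c2cc1OC` gives 13000 nM, and compound 2 `COc1cc2ncnc(Nc3ccc(NC(=O)c4cccc(I)c4)cc3)c2cc1OC` gives 30000 nM. Compound 2 therefore holds the higher of the two numbers and is the weaker inhibitor of this pair.

The next compound is compound 3 `COc1cc2ncnc(Nc3ccc(NC(=O)c4cccc(C(F)(F)F)c4)cc3)c2cc1OC`, which differs from compound 2 in a single group: trifluoromethyl in place of iodo on an aromatic carbon. Trifluoromethyl takes the place of iodo on an aromatic carbon, and the rest of the molecule stays the same.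

For the measured compounds named here, only one measured step bears on this change: a 2.3-fold higher number from compound 1 to compound 2 (0.36 log units; beyond the scatter). It involved the same aromatic carbon, with iodo in place of methyl, and it was modest. One step is a thin guide, and nothing yet shows how trifluoromethyl behaves in this series. Even so, a small change in this assay is the reasonable expectation, leaning towards a lower number, and it may not exceed the scatter. The expected step is a 1.5-fold lower number from compound 2 to compound 3 (0.18 log units; within the scatter). The estimate for compound 3 is 20000 nM, with an expected range of 8000 nM to 50000 nM.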

Compound 3, half-maximal inhibitory concentration: > 100000 nM
Compound 3: no number, only a limit (the forecaster's own chance of this, stated with the estimate: 10%); middle value at least 5.0-fold (0.69 log units) from the limit.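

At this position on the shared core, the choice of group matters more than the first pair suggested. In this assay, compound 3 gives > 100000 nM, which is a limit of the assay and not a number. Even so, the limit is enough to show an at least 3.3-fold higher number from compound 2 to compound 3 (0.52 log units; beyond the scatter) and an at least 7.6-fold higher number from compound 1 to compound 3 (0.88 log units; beyond the scatter), so replacing one group with another on this aromatic carbon can produce a larger change than the modest step seen earlier, and here the change is towards weaker inhibition.

The compounds shown carry only methyl, iodo and trifluoromethyl at this position, so it remains open whether a different group, such as an amine, a carboxylic acid or a methoxy group, would give a lower number than compound 1 or would also weaken inhibition. The full size of the two new steps also remains open, and so does the order they would take if compound 3 had an actual number, since the only reading for it is this one: the limit of > 100000 nM in this assay, at which 1 of the 3 values shown sits.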